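The source may report more compounds than this note shows. Statements on the series, on what has been measured and on what is new or still open speak of the compounds shown alone.

In an in vitro assay on HEK-tsA201 cells for antagonist activity at Neuronal acetylcholine receptor; alpha4/beta2 (Homo sapiens), read by fluorescence and calcium flux (on this read-out lower numbers stand for stronger inhibition and higher numbers for weaker inhibition), three compounds have been measured so far. Compound 1 `C=CCOc1ccc(C(=O)Nc2ccccn2)cc1` gives 19300 nM. Compound 2 `C=CCOc1ccc(C(=O)Nc2cccc(Br)n2)cc1`, which carries a bromo in place of hydrogen on an aromatic carbon of the shared core, gives 70100 nM, a weaker result: the change a 3.6-fold higher number from compound 1 to compound 2 (0.56 log units; beyond the scatter). Compound 3 `CCCCNc1cccc(NC(=O)c2ccc(OCCC)cc2)n1` gives 54100 nM, a number that sits between the other two, close enough to compound 2 to fall within the usual scatter, but clearly higher than compound 1.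

Compound 4 `CCCOc1ccc(C(=O)Nc2cccc(N3CCCCC3)n2)cc1` differs from compound 3 in one place: piperidin-1-yl in place of butylamino on an aromatic carbon. Among the compounds with values here, the only measured step, the bromo for hydrogen exchange from compound 1 to compound 2, concerns a different group at a different place and does not bear on this change. Within the data shown here, no measured pair shows what replacing an open chain amine by a ring of this kind does in this assay. With nothing to point either way, no step beyond the scatter is expected, so the estimated change is a 1.0-fold higher number from compound 3 to compound 4 (0.01 log units; within the scatter). Compound 4 is therefore expected to give about 55000 nM, with a likely range from 20000 nM to 150000 nM.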

Compound 4, half-maximal inhibitory concentration: > 100000 nM
Compound 4: a limit, no number (the forecaster's own chance of this, stated with the estimate: 20%); middle value at least 1.8-fold (0.25 log units) away from the limit.
By their numbers in this assay, from the lowest: compound 1; then compounds 3 and 2 (each within the scatter of the next). At a limit, above all of these: compound 4.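

On this aromatic carbon, next to the ring nitrogen, exchanging the open butylamino chain for the closed piperidin-1-yl ring removes the hydrogen-bond donor and gives an at least 1.8-fold higher number from compound 3 to compound 4 (0.26 log units; that floor lies within the scatter), so the ring brings no gain over the chain at this place. In this assay compound 4 has no number, only a limit, so that step is a floor and its true size stays unknown: the limit of > 100000 nM in this assay, at which 1 of the 4 values shown sits.

Because the ring and the loss of the donor arrive together, these two compounds cannot tell which of them matters. The compounds shown leave that question open, and an N-methyl-N-butylamino group, an open chain with no hydrogen on its nitrogen, would separate the two, while a smaller pyrrolidine ring would show whether ring size matters at this place.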